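Trimethoxyphenyl series, dichlorophenyl to dimethoxyphenyl on saturated ring carbon

The source may report more compounds than this note shows. Statements on the series, on what has been measured and on what is new or still open speak of the compounds shown alone.

The series is read in a functional assay on BGC-823 cells (Homo sapiens) for antiproliferative activity, read by MTT assay, tested at 5 uM; a lower number here means a weaker effect, a higher number a stronger effect of the compound at the concentration tested. Compound 1 `COc1ccc(/C=N/NC(=O)c2cc(OC)c(OC)c(OC)c2)c(OC)c1` gives 3.6%. Compound 2 `COc1cc(C2=NN(C(C)=O)C(c3c(Cl)cccc3Cl)O2)cc(OC)c1OC` gives 15.9%, the second highest of the three numbers; its nearest neighbour is compound 1, which sits lower by a gap beyond the scatter, and its furthest is compound 3 `COc1cc(C(=O)N/N=C/c2ccccc2C(F)(F)F)cc(OC)c1OC`, which gives 35.6%, higher than compound 2 by a gap also beyond the scatter. Going by the values given here, no two of these three compounds differ in a single place, so no step between measured compounds is available.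

Compound 4 `COc1ccc(C2OC(c3cc(OC)c(OC)c(OC)c3)=NN2C(C)=O)c(OC)c1` has not been measured. It differs from compound 2 as follows: 2,4-dimethoxyphenyl in place of 2,6-dichlorophenyl on a saturated ring carbon. The only measured compound carrying a 2,4-dimethoxyphenyl is compound 1, whose value of 3.6% is the lowest shown, but it sits on a different core, so it gives no direct step. In this assay the step from compound 2 to compound 4 is expected to be small, downward if anything, and likely within the scatter, as a number 5.9 percentage points lower from compound 2 to compound 4 (within the scatter). Compound 4 is accordingly estimated at 10%, with a range from 2% to 25%.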

Compound 4, a percentage reported as inhibition, at one concentration (the size of the read-out at that concentration, not a potency): -3.1%
For compound 4 the middle estimate is 13.1 percentage points above the measured one; measured number outside the range, below it.
By their numbers in this assay, from the lowest: compounds 4 and 1 (each within the scatter of the next); then compound 2; then compound 3.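

Going by these compounds alone, this is the first one-place comparison, and it shows that the aryl group on the saturated ring carbon is not a silent position. In this assay, 2,4-dimethoxyphenyl in place of 2,6-dichlorophenyl gives a number 19 percentage points lower from compound 2 to compound 4 (beyond the scatter), so on this shared core the modest inhibition seen with the dichlorophenyl group does not survive the change, and compound 4 reads -3.1%. Nothing shown offers an explanation for this step.

A single step cannot separate the loss of the chlorine atoms from the change in substitution pattern; a 2,4-dichlorophenyl or a 2,6-dimethoxyphenyl on the same carbon would pull those two apart. Going by these compounds, whether a plain phenyl at this position reads closer to compound 2 or to compound 4 also remains open.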